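The source may hold more compounds than are shown below. What is called first, only, known or untested is meant among the compounds shown, and "the series" means these compounds.

Of the compounds shown here, three share one core and have been tested in an ADME assay on MT4 cells (Homo sapiens) for cytotoxicity, read by MTT assay, with a stated time of 96 h; a lower number here means that less compound is tolerated, a higher number that more compound is tolerated. Compound 1 `O=C(CN1CCCCC1)Nc1ccc(-c2nc3cc(C(F)(F)F)ccc3[nH]2)cc1` gives 6000 nM in this assay. Compound 2 `Cn1c(-c2ccc(NC(=O)CN3CCCCC3)cc2)nc2cc(C(F)(F)F)ccc21` gives 9000 nM, and a 1.5-fold higher number from compound 1 to compound 2 (0.18 log units; within the scatter). Compound 3 `O=C(CCl)Nc1ccc(-c2nc3cc(C(F)(F)F)ccc3[nH]2)cc1` gives 5000 nM, and a 1.2-fold lower number from compound 1 to compound 3 (0.08 log units; within the scatter). The three numbers therefore sit within the usual scatter of one another, so nothing separates compound 3 from the others beyond what repeated measurement would show.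

Compound 4 `Oc1ccc(-c2nc3cc(C(F)(F)F)ccc3[nH]2)cc1` is the untested compound. Compared with compound 3, the change is hydroxy in place of ((chloromethyl)carbonyl)amino on an aromatic carbon. For the measured compounds named here, the only measured step that touches the same side of the molecule is the one from compound 1 to compound 3, which swapped the end of the chain and left the number within the scatter. Going by the values given here, no measured step removes the whole amide chain, so the present change goes further than anything already seen. Among the compounds with values here, with the three known numbers so close together, the expectation is a step of a 1.2-fold higher number from compound 3 to compound 4 (0.08 log units; within the scatter), which is not beyond the scatter. Compound 4 is therefore estimated to give 6000 nM in this assay, within a range of 2000 nM to 20000 nM.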

Compound 4, half-maximal cytotoxic concentration: 17000 nM
Compound 4: middle estimate off by 2.8-fold (0.45 log units), on the low side; low and high end bracket the measured number.
By their numbers in this assay, from the lowest: compounds 3, 1, 2 and 4 (each within the scatter of the next, the first and the last beyond it).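

In this assay, putting hydroxy in place of ((chloromethyl)carbonyl)amino on an aromatic carbon para to a large group gives a 3.4-fold higher number from compound 3 to compound 4 (0.53 log units; beyond the scatter), the only step shown that lies beyond the scatter, though a modest one. This shows that the whole amide chain can leave this position and the cells tolerate more compound, not less, whereas changing only the end of the chain gave a 1.2-fold lower number from compound 1 to compound 3 (0.08 log units; within the scatter) and stayed within the scatter. No measurement at hand bears on the cause of the new step.

From the compounds shown here alone, it remains open whether hydroxy itself matters or only the loss of the chain, which a methoxy group, an amine or a carboxylic acid at this position could help to separate. Also open, going by these compounds, is whether methyl on the aromatic nitrogen, as in compound 2, would leave the number unchanged with hydroxy in place.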